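The source may report more compounds than this note shows. Statements on the series, on what has been measured and on what is new or still open speak of the compounds shown alone.

Three chalcone-type compounds built on a shared core have been measured. Compound 1 `CC(C)(C)c1ccc(C(=O)/C=C/c2ccncc2)cc1` gives 47000 nM in a functional assay with Rattus norvegicus as the target; on this read-out lower numbers stand for stronger inhibition and higher numbers for weaker inhibition; compound 2 `CN(C)c1ccc(C(=O)/C=C/c2ccncc2)cc1` gives 11000 nM; compound 3 `O=C(/C=C/c1ccncc1)c1ccccc1` gives 49000 nM. On these numbers compound 3 has the highest value of the three, with compound 1 nearest (a 1.0-fold higher number from compound 1 to compound 3 (0.02 log units; within the scatter)) and compound 2 furthest (a 4.5-fold higher number from compound 2 to compound 3 (0.65 log units; beyond the scatter)), so compound 3 and compound 1 cannot be told apart while compound 2 stands clearly apart from both.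

Compound 4 `O=C(/C=C/c1ccncc1)c1cccc(Cl)c1` is the next in line. Its difference from compound 3 is chloro in place of hydrogen on an aromatic carbon. Among the measured compounds shown here, no measured step involves a chloro group; the swaps seen so far, tert-butyl for hydrogen (a 1.0-fold higher number from compound 1 to compound 3 (0.02 log units; within the scatter)) and dimethylamino for hydrogen (a 4.5-fold higher number from compound 2 to compound 3 (0.65 log units; beyond the scatter)), show that one group swap left the number unchanged within the scatter and another moved it modestly. With nothing closer to rest on, the step is expected to be a 1.2-fold lower number from compound 3 to compound 4 (0.09 log units; within the scatter), that is, nothing beyond the scatter. Compound 4 is therefore estimated at 40000 nM, within a range from 15000 nM to 110000 nM.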

Compound 4, half-maximal inhibitory concentration: 69000 nM
Compound 4: middle estimate off by 1.7-fold (0.24 log units), on the low side; the range from low to high includes it.
By their numbers in this assay, from the lowest: compound 2; then compounds 1, 3 and 4 (each within the scatter of the next).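

In this assay, compound 4 is the only compound shown with a group at this place, meta to a large group, and putting chloro there gives a 1.4-fold higher number from compound 3 to compound 4 (0.15 log units; within the scatter). Among the compounds shown here, this place on the ring therefore takes a chloro group without a change that can be told from the scatter, and compound 2, with its dimethylamino group at another place, remains the only compound clearly apart from the rest. Nothing shown accounts for why the chloro step stays so small.

With a single group at this place, the compounds shown cannot tell whether the place is insensitive to change in general or whether chloro alone leaves the number where it is. A methoxy group or a carboxylic acid at the same place might move the number beyond the scatter, and the compounds shown do not settle this.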